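The compounds below may be only part of what the source reports. "The series", "measured", "known", "first", "only" and "open" are said of these compounds alone.

Measured in a functional assay on Z-138 cells (Homo sapiens) for antiproliferative activity, with a stated time of 72 h; a higher number here means a weaker inhibitor, a lower number a stronger inhibitor:
- compound 1 `CCCC#Cc1cc([C@@H]2O[C@H](CO)[C@@H](O)[C@H]2O)n2ncnc(N)c12`: 20 nM
- compound 2 `Nc1ncnn2c([C@@H]3O[C@H](CO)[C@@H](O)[C@H]3O)cc(-c3ccc(F)cc3)c12`: > 100000 nM (a limit of the assay)

Compound 2 has no exact number, and its value of > 100000 nM is only a limit. The record for the pair reads: the limit of > 100000 nM in this assay, at which 1 of the 2 values shown sits.

Compound 3 `Cc1ccccc1-c1cc([C@@H]2O[C@H](CO)[C@@H](O)[C@H]2O)n2ncnc(N)c12` changes compound 2 in one place, with 2-methylphenyl in place of 4-fluorophenyl on an aromatic carbon. Within the data shown here, no measured step compares these two groups directly.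

The nearest evidence comes from the same position. Replacing pent-1-yn-1-yl with 4-fluorophenyl gave an at least 5000-fold higher number from compound 1 to compound 2 (3.69 log units; beyond the scatter), a large step beyond the scatter. Compound 3 resembles compound 2 rather than compound 1 at this position, as it also carries a six-membered aromatic ring of carbon only. It is therefore expected to stay far from compound 1 and close to compound 2. In this assay, only a modest move towards a lower number is expected, if any, and compound 3 may also return only a limit.

The estimated change is an at least 2.0-fold lower number from compound 2 to compound 3 (0.30 log units; that floor lies within the scatter). For compound 3 the expected value is 50000 nM, with an estimated range of 5000 nM to 100000 nM.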

Compound 3, half-maximal inhibitory concentration: 66000 nM
For compound 3 the middle estimate is 1.3-fold (0.12 log units) below the measured one; the measured number falls inside the stated range.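

The change from pent-1-yn-1-yl to a six-membered aromatic ring of carbon only now has a second example, and the loss is not confined to 4-fluorophenyl: in this assay, 2-methylphenyl gives a 3300-fold higher number from compound 1 to compound 3 (3.52 log units; beyond the scatter). Between the two rings, the data give an at least 1.5-fold lower number from compound 2 to compound 3 (0.18 log units; that floor lies within the scatter), so moving from 4-fluorophenyl to 2-methylphenyl cannot be said to make a real difference, and the two groups cannot be ranked. Compound 2 has only a limit of the assay, which leaves the true size of that step unknown: the limit of > 100000 nM in this assay, at which 1 of the 3 values shown sits.

The compounds shown do not separate the effect of the triple bond from that of the chain it carries, so it remains open whether a saturated pentyl chain, a shorter prop-1-yn-1-yl group or a longer alkyne would stay close to compound 1. They also leave open whether any ring can be tolerated at this position, for instance a phenyl ring carried on an alkyne, or whether a group bearing an amine or a hydroxyl would fare differently.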